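A few compounds are considered here, and "the series" means these few. Any claim that something is new, unique, unknown or untested is made for them only; others in the source may bear on it.

Measured so far in a functional assay on MCF7 cells (Homo sapiens) for antiproliferative activity; a lower number here means a stronger inhibitor, a higher number a weaker inhibitor:

compound 1 `COc1ccc(Oc2ccc3cc(NC(=O)c4ccc(O)c(CC=C(C)C)c4)c(=O)oc3c2C)cc1`: 6510 nM
compound 2 `COc1cccc(Oc2ccc3cc(NC(=O)c4ccc(O)c(CC=C(C)C)c4)c(=O)oc3c2C)c1`: 62800 nM
compound 3 `COc1ccc(Oc2ccc3cc(NC(=O)c4ccc(OC)c(-c5cccc(OC)c5)c4)c(=O)oc3c2C)cc1`: the assay reports only a limit, > 100000 nM

Compound 1 and compound 2 share one core and differ in a single place, (3-methoxyphenyl in place of 4-methoxyphenyl on an oxygen on an aromatic ring). That change costs potency: a 9.6-fold higher number from compound 1 to compound 2 (0.98 log units; beyond the scatter), so compound 2 is the weaker inhibitor of the pair in this assay.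

Compound 3 carries a different amide part; the difference between the core of compound 1 and the core of compound 3 is not broken down here. For compound 3 this assay gives no number, only a limit, the value sitting at the limit of > 100000 nM in this assay, at which 1 of the 3 values shown sits.

Compound 4 `COc1cccc(Oc2ccc3cc(NC(=O)c4ccc(OC)c(-c5cccc(OC)c5)c4)c(=O)oc3c2C)c1` has not yet been measured in this assay. It stands to compound 3 as compound 2 stands to compound 1: the change is 3-methoxyphenyl in place of 4-methoxyphenyl on an oxygen on an aromatic ring, the same change in the same place as before.

The step from compound 3 to compound 4 is expected to be a step that the limit leaves unreadable from compound 3 to compound 4, an expectation that rests on the step of a 9.6-fold higher number from compound 1 to compound 2 (0.98 log units; beyond the scatter), which went in the weakening direction. Since compound 3 already sits at a limit, compound 4 is expected to remain beyond that limit, with an estimated value of 500000 nM in this assay, between 100000 nM and 3000000 nM; most likely the assay will again report only a limit for compound 4.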

Compound 4, half-maximal inhibitory concentration: > 100000 nM
Compound 4 gave a limit, no number; the forecaster's own chance of this, stated with the estimate: 90%; the middle value does not contradict the limit.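

In this assay, compound 3 and compound 4 both give a limit and not a number, so the step between them cannot be read: the limit of > 100000 nM in this assay, at which 2 of the 4 values shown sit.

The compounds shown leave open whether the change from 4-methoxyphenoxy to 3-methoxyphenoxy has the same effect on the core of compound 3 as on the core of compound 1.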